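Pyrrolidinyl Amide in Place of Dimethylaminoethyl: Expected Clearance

The compounds below may be only part of what the source reports. "The series", "measured", "known", "first", "only" and "open" are said of these compounds alone.

In an ADME assay on cells (Hepatocyte, Rattus norvegicus) for metabolic stability (a lower number here means slower removal, a higher number faster removal of the compound), compound 1 `Cc1ccc2[nH]c(C(=O)N[C@H]3CN(S(=O)(=O)c4ccccc4)C[C@@H]3C(=O)NCCN(C)C)cc2c1` gives 16 uL/min, the highest of the three numbers measured. Compound 2 `Cc1ccc2[nH]c(C(=O)N[C@H]3CN(S(=O)(=O)c4cnccn4)C[C@@H]3C(=O)NCCN(C)C)cc2c1` gives 12 uL/min and compound 3 `Cc1ccc2[nH]c(C(=O)N[C@H]3CN(S(=O)(=O)C4CCOCC4)C[C@@H]3C(=O)NCCN(C)C)cc2c1` gives 4 uL/min; the two changes on the sulfonyl sulfur give a 1.3-fold lower number from compound 1 to compound 2 (0.12 log units; within the scatter) and a 4.0-fold lower number from compound 1 to compound 3 (0.60 log units; beyond the scatter). Compound 4 `Cc1ccc2[nH]c(C(=O)N[C@H]3CN(S(=O)(=O)c4ccccc4)C[C@@H]3C(=O)NC[C@H]3CCCN3)cc2c1` differs from compound 1 elsewhere: pyrrolidin-2-yl in place of (dimethylamino)methyl on a saturated chain carbon bound to an amide-type nitrogen. Within the data shown here, no measured step touches the chain on the amide-type nitrogen, so the sulfonyl comparisons show only the span this series has covered and do not bear directly on the new change. Compound 4 is therefore expected to stay within the scatter of compound 1, a step of no change at the digits printed from compound 1 to compound 4 (within the scatter). The estimate for compound 4 is 16 uL/min, ranging from 8 uL/min to 32 uL/min.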

Compound 4, intrinsic clearance in a liver preparation (reported as CLH), per the amount of preparation that the assay uses: 10 uL/min
Beside the measured number, compound 4's estimate is 1.6-fold (0.20 log units) above it, and the stated range covers the measured number.
By their numbers in this assay, from the lowest: compound 3; then compounds 4, 2 and 1 (each within the scatter of the next).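

In this assay, among these compounds, pyrrolidin-2-yl in place of (dimethylamino)methyl on a saturated chain carbon bound to an amide-type nitrogen gives a 1.6-fold lower number from compound 1 to compound 4 (0.20 log units; within the scatter), the first reading at this position, which the sulfonyl steps left untouched. A five-membered non-aromatic ring with a defined stereocentre and a hydrogen-bond donor is thus accommodated here with no step beyond the scatter. No supporting data on the structural basis of this result are available.

From the compounds shown here alone, it remains open how piperidin-2-yl or a longer chain would read at this position. Going by these compounds, it is also open whether pyrrolidin-2-yl would give a similar step alongside oxan-4-yl on the sulfonyl sulfur.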